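The source may hold more compounds than are shown below. What is called first, only, known or untested is meant among the compounds shown, and "the series" means these compounds.

Measured so far:
compound 1, `CC[C@H](C)[C@H]1C(=O)N[C@H](Cc2cc(Cl)c(O)c(Cl)c2)C(=O)N[C@@H](C(C)(C)O)C(=O)O[C@H](c2ccccc2)[C@H](C)/C=C/C=C(\C)[C@H](OC)C[C@@H]2O[C@@]2(C)C(=O)N1C`: 2.11 nM
compound 2, `CC[C@H](C)[C@H]1C(=O)N[C@H](Cc2ccc(O)c(Br)c2)C(=O)N[C@@H](C(C)(C)O)C(=O)O[C@H](c2ccccc2)[C@H](C)/C=C/C=C(\C)[C@H](OC)C[C@H]2O[C@]2(C)C(=O)N1C`: > 200 nM

Compound 1 gives 2.11 nM in a functional assay on HCT-116 cells (Homo sapiens) for antiproliferative activity; a lower number here means a stronger inhibitor, a higher number a weaker inhibitor. Among the compounds with values here, compound 2 gives only a limit in this assay, > 200 nM, so no number is known for it; this is the limit of > 200 nM in this assay, at which 1 of the 2 values shown sits, and no step between the two can be computed, since they differ in more than one place.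

Compound 3, `CC[C@H](C)[C@H]1C(=O)N[C@H](Cc2cc(Cl)c(O)c(Cl)c2)C(=O)N[C@@H](C(C)(C)O)C(=O)O[C@H](c2ccccc2)[C@H](C)/C=C/C=C(\C)[C@H](OC)C[C@H]2O[C@]2(C)C(=O)N1C`, has not yet been measured. It is built from compound 2 by one change: 3,5-dichloro-4-hydroxyphenyl in place of 3-bromo-4-hydroxyphenyl on a saturated chain carbon bound to a saturated ring carbon. Compound 3 therefore carries the same ring substitution as compound 1, but the rest of its structure it shares with compound 2, which sits at the limit.

Without a measured step for this change the size is open. Compound 3 is expected to move toward stronger inhibition than compound 2, by an at least 1.3-fold lower number from compound 2 to compound 3 (0.12 log units; that floor lies within the scatter), though with a good chance that this assay again reports only a limit. Compound 3 is estimated at 150 nM, between 20 nM and 1500 nM.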

Compound 3, half-maximal inhibitory concentration: > 200 nM
Compound 3: a limit, no number (the forecaster's own chance of this, stated with the estimate: 50%); at least 1.3-fold (0.12 log units) between middle value and limit.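

In this assay compound 3 gives only a limit, so the step for 3,5-dichloro-4-hydroxyphenyl in place of 3-bromo-4-hydroxyphenyl cannot be read: the limit of > 200 nM in this assay, at which 2 of the 3 values shown sit. Within the data shown here, what the earlier compounds did not show is the weight of configuration: with 3,5-dichloro-4-hydroxyphenyl held fixed, the two stereocentres at saturated ring carbons that differ give an at least 94-fold higher number from compound 1 to compound 3 (1.97 log units; beyond the scatter). This large loss can be assigned to the configuration as drawn, not to any change in atoms or bonds, because of this: the fact that compounds 1 and 3 differ only in the configuration as drawn.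

The compounds shown leave open whether 3-bromo-4-hydroxyphenyl would hold activity in the configuration of compound 1, and whether either stereocentre alone accounts for the loss. They also leave open what an unsubstituted phenyl, or fluorine in place of chlorine, would do on this saturated chain carbon.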